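The source may report more compounds than this note shows. Statements on the series, on what has been measured and on what is new or still open speak of the compounds shown alone.

Measured so far:
compound 1 `O=C(NC1CCN(C2CC2)C1)c1cc(-c2ccc(NS(=O)(=O)c3cccc(Cl)c3Cl)cc2)nc2[nH]ncc12` — 610 nM
compound 2 `CC(C)NC(=O)c1cc(-c2ccc(NS(=O)(=O)c3cccc(Cl)c3Cl)cc2)nc2[nH]ncc12` — 17600 nM

In an assay for inhibition of serine/threonine-protein kinase Sgk1 (Homo sapiens), with stated times of 30 min and 60 min, in the presence of a further agent that is not named here (a lower number here means a stronger inhibitor, a higher number a weaker inhibitor), compound 2 gives the highest number of the two, and its nearest neighbour is compound 1. Within the data shown here, the one step measured here, a 29-fold higher number from compound 1 to compound 2 (1.46 log units; beyond the scatter), shows that what sits on the amide-type nitrogen moves the number strongly. Compound 3 `NCCNC(=O)c1cc(-c2ccc(NS(=O)(=O)c3cccc(Cl)c3Cl)cc2)nc2[nH]ncc12` carries the change (2-aminoethyl in place of isopropyl on an amide-type nitrogen). Because a 29-fold higher number from compound 1 to compound 2 (1.46 log units; beyond the scatter) was large, a step of clear size is expected here as well, and since the entering group, like that of compound 1, brings a nitrogen rather than carbon alone, the expected direction is downward: a 7.0-fold lower number from compound 2 to compound 3 (0.85 log units; beyond the scatter). Compound 3 is therefore estimated at 2500 nM, within 500 nM to 12000 nM.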

Compound 3, half-maximal inhibitory concentration: < 1 nM
Compound 3: a limit, no number; the forecaster's own chance of this, stated with the estimate: 5%; at least 2500-fold (3.39 log units) between middle value and limit.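

Putting 2-aminoethyl in place of isopropyl, a swap of one carbon for one nitrogen within the same 3 heavy atoms, gives an at least 17000-fold lower number from compound 2 to compound 3 (4.24 log units; beyond the scatter). Compound 3 gives < 1 nM, which is a limit and not a number. Nitrogen alone does not set the level at this position, since both groups in the other step carry it, and the open chain still gives an at least 610-fold lower number from compound 1 to compound 3 (2.78 log units; beyond the scatter).

As far as these compounds go, how far compound 3 lies past its limit stays open. So does whether a longer chain such as 3-aminopropyl, or 2-hydroxyethyl with its oxygen where the amine stands, would hold this level.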